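Dropping the para-chloro from the benzylidene hydrazide

A few compounds are considered here, and "the series" means these few. Any claim that something is new, unique, unknown or untested is made for them only; others in the source may bear on it.

Compound 1 `COc1ccc(OC)c(/C=C/c2nnc(Nc3ccc(Cl)cc3)o2)c1`: 7940 nM
Compound 2 `COc1ccc(OC)c(/C=C/C(=O)N/N=C/c2ccc(Cl)cc2)c1`: 1170 nM

In a functional assay on SNB-75 cells (Homo sapiens) for antiproliferative activity, read by sulforhodamine B assay, with a stated time of 48 h (a higher number here means a weaker inhibitor of growth, a lower number a stronger inhibitor of growth), compound 2 stands lowest of the two numbers; compound 1 gives the higher number, and that gap lies beyond the scatter. Compound 3 `COc1ccc(OC)c(/C=C/C(=O)N/N=C/c2ccccc2)c1` differs from compound 2 in one place: hydrogen in place of chloro on an aromatic carbon. Going by the values given here, no measured step of this kind is available, so its size is estimated. A modest rise in the number is expected, a step of about a 1.9-fold higher number from compound 2 to compound 3 (0.27 log units; within the scatter), which may lie only a little beyond the scatter. Compound 3 is therefore expected to give 2200 nM, within a range of 800 nM to 6500 nM.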

Compound 3, concentration for total growth inhibition: 37300 nM
For compound 3 the middle estimate is 17-fold (1.23 log units) below the measured one; the whole stated range lies below it.
By their numbers in this assay, from the lowest: compound 2; then compound 1; then compound 3.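

Within this assay the 4-chlorophenyl to phenyl change brings a 32-fold higher number from compound 2 to compound 3 (1.50 log units; beyond the scatter) and so shows that this place on the aromatic ring is far from indifferent to what it carries. A single chlorine atom, with no ring, no hydrogen-bond donor or acceptor and no net charge, separates the two compounds, so the whole step rests on that one replacement. Nothing shown here gives a reason for a step of this size. Going by these compounds, whether a fluoro, a methoxy or an amine at this place would keep the growth inhibition of compound 2 stays open, as does the effect of the same replacement on the core of compound 1.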